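The compounds below may be only part of what the source reports. "The series", "measured", "known", "first", "only" and "open" are said of these compounds alone.

Among the compounds with values here, in a functional assay on L1210 cells (Mus musculus) for inhibition (on this read-out lower numbers stand for stronger inhibition and higher numbers for weaker inhibition), compound 1 `Nc1ncnc2c1ncn2C/C=C/CCl` gives 45000 nM, the only actual number so far. Compound 2 `Cc1cn(CC#CCO)c(=O)[nH]c1=O` is reported only as a limit, > 500000 nM. That leaves compound 1 with no measured number to be ranked against, and its modest inhibition is the sole anchor for what follows.

Compound 3 `Nc1ncnc2c1ncn2/C=C\CCO` keeps the core of compound 1 and changes only the chain on the aromatic nitrogen of the five-membered aromatic ring: 4-hydroxybut-1-en-1-yl in place of 4-chlorobut-2-en-1-yl on an aromatic nitrogen. In words, 4-hydroxybut-1-en-1-yl stands in place of 4-chlorobut-2-en-1-yl, so the chlorine is gone and the chain now ends in a hydroxy group.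

Within the data shown here, no measured pair differs in one place, so the size of this change rests on judgement alone. A shift towards weaker inhibition, beyond the usual scatter, is expected in this assay, starting from the 45000 nM of compound 1. The expected size is a 3.3-fold higher number from compound 1 to compound 3 (0.52 log units; beyond the scatter). Compound 3 is estimated at 150000 nM, with an expected range of 50000 nM to 500000 nM.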

Compound 3, half-maximal inhibitory concentration: 200000 nM
Estimate against measurement, compound 3: 1.3-fold (0.12 log units) below, within the range that was stated.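

In this assay, within the data shown here, placing 4-hydroxybut-1-en-1-yl instead of 4-chlorobut-2-en-1-yl on the aromatic nitrogen of the shared core gives the first readable step, a 4.4-fold higher number from compound 1 to compound 3 (0.65 log units; beyond the scatter). Compound 3 still gives an actual number, 200000 nM, so at this position a chain ending in a hydroxy group weakens inhibition without leaving the measurable range, even though the two chains match in heavy-atom count. Compound 2, which does not share the core of compound 1, is a limit of the assay and not a number: the limit of > 500000 nM in this assay, at which 1 of the 3 values shown sits.

Among these compounds, the single step moves the double bond along the chain and replaces the chlorine with a hydroxy group at the same time, so the share of each change cannot be read from it. Open questions are how 4-hydroxybut-2-en-1-yl, which would keep the double bond of compound 1, compares on this nitrogen, and whether a chain ending in an amine or a carboxylic acid follows compound 1 or compound 3.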